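Bromo on the phenoxy ring of compound 2

The source may report more compounds than this note shows. Statements on the series, on what has been measured and on what is new or still open speak of the compounds shown alone.

Within the data shown here, compound 2 `COc1cc2c(cc1CC=C(C)C)C(=O)C[C@@H](c1ccc(Oc3ccccc3)cc1)O2` is one of three compounds measured in a functional assay on HCT-116 cells (Homo sapiens) for inhibition, read by sulforhodamine B assay, with a stated time of 48 h, tested at 50 uM; a lower number here means less inhibition of growth, a higher number more inhibition of growth at the concentration tested; compound 2 gives 76%, the second highest of the three. Compound 1 `COc1ccc([C@@H]2C/C(=N/OCc3cn(-c4ccccc4CO)nn3)c3cc(CC=C(C)C)c(OC)cc3O2)cc1` gives 100% in this assay, and compound 3 `COc1ccc([C@@H]2C/C(=N/OCc3cn(-c4ccc(O)cc4)nn3)c3cc(CC=C(C)C)c(OC)cc3O2)cc1` gives 65%. Among the measured compounds shown here, the one measured step that joins two compounds differing in one place is a number 35 percentage points lower from compound 1 to compound 3 (beyond the scatter), a change on an aromatic nitrogen of a scaffold that compound 2 does not share, so it does not bear on the change at hand. Compound 4 `COc1cc2c(cc1CC=C(C)C)C(=O)C[C@@H](c1ccc(Oc3ccc(Br)cc3)cc1)O2` differs from compound 2 by bromo in place of hydrogen on an aromatic carbon. For the measured compounds named here, no measured pair adds a bromo, so there is nothing to set the size of the step from. The working expectation is therefore that compound 4 stays close to compound 2, with a number 2 percentage points higher from compound 2 to compound 4 (within the scatter) estimated to lie within the usual scatter. Compound 4 is expected to give about 78% in this assay, estimated between 60% and 95%.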

Compound 4, percent growth inhibition at one concentration: 76%
The estimate for compound 4 lay 2 percentage points above the measured number; the measured number falls inside the stated range.
By their numbers in this assay, from the lowest: compound 3; then compounds 2 and 4 (each within the scatter of the next); then compound 1.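

In this assay, bromo in place of hydrogen on the phenoxy ring, para to a large group, gives no change at the digits printed from compound 2 to compound 4 (within the scatter), so compound 4 at 76% cannot be told apart from compound 2. Among these compounds, this is the only measured step on this ring, and it shows that this position can carry a single bromine atom without a shift beyond the scatter at the one concentration tested. No evidence here bears on why the number holds.

As far as these compounds go, whether an amine, a carboxylic acid or a longer chain at this position would leave the number in place remains open. Also open, from the compounds shown here alone, is whether compound 2 and compound 4 would stay within the scatter of each other at lower concentrations, where growth inhibition at this level might not hold.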